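Third aryl variant on the aromatic-ring nitrogen: compound 3

This account rests on a few compounds, and the source may have more. Where it says the series, first, only, none or still open, it means among the compounds named here.

Compound 1 `C=CC(=O)Nc1cccc(NC(=O)CSc2nc(Nc3ccccc3Cl)c3ccccc3n2)c1` and compound 2 `C=CC(=O)Nc1cccc(NC(=O)CSc2nc(Nc3cccc(OC)c3)c3ccccc3n2)c1` share one core and differ only in the aryl group on a nitrogen on an aromatic ring. In a functional assay on MDA-MB-231 cells (Homo sapiens) for inhibition, read by MTT assay, with a stated time of 72 h (on this read-out higher numbers stand for weaker inhibition and lower numbers for stronger inhibition), compound 1 gives 12700 nM and compound 2 gives 12900 nM; the step of a 1.0-fold higher number from compound 1 to compound 2 (0.01 log units; within the scatter) lies within the scatter. Compound 2 thus holds the highest of the two numbers, with compound 1 nearest and within the scatter of it, so no order between them is claimed. Compound 3 `C=CC(=O)Nc1cccc(NC(=O)CSc2nc(Nc3ccc(F)cc3)c3ccccc3n2)c1` carries the change (4-fluorophenyl in place of 3-methoxyphenyl on a nitrogen on an aromatic ring). Among the compounds with values here, the one measured step that bears on it, a 1.0-fold higher number from compound 1 to compound 2 (0.01 log units; within the scatter), is an aryl swap at the same place and moved nothing beyond the scatter, so for compound 3 no step beyond the scatter is expected in this assay in either direction. Compound 3 is accordingly expected near 12800 nM, in the range 5500 nM to 30000 nM. The expected step is a 1.0-fold lower number from compound 2 to compound 3 (0.00 log units; within the scatter).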

Compound 3, half-maximal inhibitory concentration: 9490 nM
Estimate against measurement, compound 3: 1.3-fold (0.13 log units) above, within the range that was stated.
By their numbers in this assay, from the lowest: compounds 3, 1 and 2 (each within the scatter of the next).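

In this assay, the swap to 4-fluorophenyl on this nitrogen gives a 1.4-fold lower number from compound 2 to compound 3 (0.13 log units; within the scatter) and a 1.3-fold lower number from compound 1 to compound 3 (0.13 log units; within the scatter). The flat reading at this position therefore now spans three aryl groups, 2-chlorophenyl, 3-methoxyphenyl and 4-fluorophenyl, rather than a single pair, and no order among them can be claimed. No supporting data bear on why these groups read alike.

Still open, from the compounds shown here alone, is whether any group on this nitrogen can move the number beyond the scatter, since all three compounds carry a singly substituted phenyl ring there. A phenyl ring bearing a carboxylic acid or a dimethylamino group, or a longer chain such as benzyl in place of the directly attached aryl ring, would test how far this flat reading extends.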